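The compounds below may be only part of what the source reports. "The series", "measured", "known", "first", "only" and "open" are said of these compounds alone.

Measured compounds in an assay on isolated protein for inhibition of endoplasmic reticulum aminopeptidase 2 (Homo sapiens); a higher number here means a weaker inhibitor, a lower number a stronger inhibitor:
compound 1 `CC(C)(NC(=O)c1cc(F)cc2cc(-c3ccc(Cl)cc3)oc12)C(N)=O` — "not determined" (no result reported).
compound 2 `C[C@H](NC(=O)c1cc(F)cc2cc(-c3ccc(Cl)cc3)oc12)C(=O)O` — "not determined" (no result reported).
compound 3 `O=C(NC1(C(=O)O)CCCCC1)c1cc(F)cc2cc(-c3ccc(Cl)cc3)oc12` — a limit of > 30000 nM, not a number.

Compound 3 therefore stands at the weak end of the assay's range, at the limit of > 30000 nM in this assay, at which 1 of the 3 values shown sits, and with no single number for compound 1 or compound 2 it cannot be placed relative to either. For the measured compounds named here, no measured step between two compounds exists in this set.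

Compound 4 `O=C(NC1(C(=O)O)CCCCC1)c1cccc2cc(-c3ccc(Cl)cc3)oc12` differs from compound 3 by hydrogen in place of fluoro on an aromatic carbon. Going by the values given here, no measured pair covers this change, so no direction can be read from the data. The expectation is that the step from compound 3 to compound 4 in this assay is none beyond the scatter, a number no higher from compound 3 to compound 4 (the limit leaves the size open). Compound 4 is accordingly estimated at 30000 nM in this assay, with a range from 10000 nM to 100000 nM.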

Compound 4, half-maximal inhibitory concentration: > 30000 nM
Compound 4: no number, only a limit; the forecaster's own chance of this, stated with the estimate: 70%; the middle value sits exactly at the limit.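

In this assay, for the compounds shown here, compound 3 and compound 4 both end at a limit, not a number, so no step between them can be read: the limit of > 30000 nM in this assay, at which 2 of the 4 values shown sit.

The compounds shown leave open whether hydrogen in place of fluoro on an aromatic carbon changes the inhibition at all.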